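Phenyl to methyl on the side chain

The source may hold more compounds than are shown below. What is called first, only, known or untested is meant among the compounds shown, and "the series" means these compounds.

Values so far in a functional assay on HeLa cells (Homo sapiens) for cytotoxicity; a lower number here means a stronger inhibitor, a higher number a weaker inhibitor
compound 1 `C=CCOc1ccc2c(c1)C(=O)C=CC2=O` gives 27200 nM
compound 2 `O=C1C=CC(=O)c2cc(OCc3ccccc3)ccc21` gives 16800 nM

For the measured compounds named here, only one measured step exists so far, and it is a 1.6-fold lower number from compound 1 to compound 2 (0.21 log units; within the scatter), so compound 2 stands level with its sole neighbour within the scatter. Next comes compound 3 `CCOc1ccc2c(c1)C(=O)C=CC2=O`, which differs from it by methyl in place of phenyl on a saturated chain carbon bound to an oxygen on an aromatic ring. The measured step changed the group at this same place and stayed within the scatter, but it is thin support, and methyl has not yet been measured there. No step beyond the scatter is therefore expected in this assay, and no firm direction. The estimated change is a 1.3-fold higher number from compound 2 to compound 3 (0.12 log units; within the scatter) and is expected to stay within the scatter. For compound 3 the estimate is 22000 nM, with an expected range from 11000 nM to 45000 nM.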

Compound 3, half-maximal inhibitory concentration: 25100 nM
Beside the measured number, compound 3's estimate is 1.1-fold (0.06 log units) below it; the range from low to high includes it.
By their numbers in this assay, from the lowest: compounds 2, 3 and 1 (each within the scatter of the next).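

In this assay, methyl in place of phenyl on a saturated chain carbon bound to an oxygen on an aromatic ring gives a 1.5-fold higher number from compound 2 to compound 3 (0.17 log units; within the scatter), and methyl in place of vinyl at the same place gives a 1.1-fold lower number from compound 1 to compound 3 (0.03 log units; within the scatter), so all three steps among these compounds now lie within the scatter. For the compounds shown here, the series thus shows that, in this small set, going from phenyl with its 6 heavy atoms and six-membered aromatic ring to methyl with 1 heavy atom and no ring leaves the read-out level, which the single earlier step could not show. No evidence on why the values stay level is at hand.

From the compounds shown here alone, whether an amine, a carboxylic acid or a longer chain at this place would produce a step beyond the scatter remains open. So does whether any change to the shared core, which all three compounds carry unchanged, would do so.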